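The source may report more compounds than this note shows. Statements on the series, on what has been measured and on what is new or still open speak of the compounds shown alone.

Of the compounds shown here, two have been measured so far in a functional assay on HL-60 cells (Homo sapiens) for inhibition, read by CCK-8 assay, with a stated time of 48 h, tested at 20 uM; on this read-out lower numbers stand for less inhibition of growth and higher numbers for more inhibition of growth at the one concentration tested. Compound 1 `COc1ccc(S(=O)(=O)Oc2ccccc2/C=C(\C#N)C(=O)Nc2nnc(Cc3ccc(F)cc3)s2)cc1` gives 100%. Compound 2 `N#C/C(=C\c1ccccc1OS(=O)(=O)c1ccc(Cl)cc1)C(=O)Nc1nnc(Cc2ccc(F)cc2)s1` gives 20%, the lower of the two numbers and well beyond the scatter from compound 1.

Compound 3 `N#C/C(=C\c1ccccc1OS(=O)(=O)c1ccc(F)cc1)C(=O)Nc1nnc(Cc2ccc(F)cc2)s1` is identical to compound 2 except for one substituent: fluoro in place of chloro on an aromatic carbon. Here fluoro replaces chloro, para to a large group.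

Among the compounds with values here, only one measured step bears on this change. It concerns the same place on the same ring: a number 80 percentage points lower from compound 1 to compound 2 (beyond the scatter), with chloro in place of methoxy. That step is large, so a single substituent here can move the result in this assay a long way. Within the data shown here, no measured compound carries fluoro at this place, however, so the step gives only a rough guide. With compound 2 at 20%, there is much more room for a rise than for a fall.

The expected change is modest and upward, much smaller than the measured step, and is estimated as a number 15 percentage points higher from compound 2 to compound 3 (beyond the scatter). Compound 3 is estimated at 35%, with an expected range from 10% to 75%.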

Compound 3, percent growth inhibition at one concentration: 13%
Beside the measured number, compound 3's estimate is 22 percentage points above it, within the range that was stated.
By their numbers in this assay, from the lowest: compounds 3 and 2 (each within the scatter of the next); then compound 1.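

In this assay, exchanging one halogen for the other at this place, 4-chlorophenyl to 4-fluorophenyl, makes no real difference: the result reads a number 7 percentage points lower from compound 2 to compound 3 (within the scatter) and so gives no sign that the choice of halogen matters here. The methoxy group, by contrast, now stands apart from two different halogens, not just one, with a second large step reading a number 87 percentage points lower from compound 1 to compound 3 (beyond the scatter), so the drop first seen with chloro is not peculiar to chloro. Among these three compounds, then, compound 1 alone gives a high number, but nothing measured here explains what sets methoxy apart from the two halogens.

On these data alone, it remains open whether the high number belongs to methoxy alone or extends to other groups at this place, such as ethoxy, a hydroxyl, an amine or a methyl, and whether bromo would behave like chloro and fluoro. With only one concentration tested, compound 1 at 100% also leaves open how much lower a concentration would still give full inhibition of growth.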